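The compounds below may be only part of what the source reports. "The series", "measured", "known", "first", "only" and "open" are said of these compounds alone.

Compound 1 `O=[N+]([O-])c1ccccc1/C=N\NC(=S)N(Cc1ccccc1)Cc1ccccc1` was examined in an ADME assay on Vero cells (Chlorocebus sabaeus) for cytotoxicity, read by MTT assay, with a stated time of 72 h; a higher number here means that more compound is tolerated, a lower number that less compound is tolerated. In this assay compound 1 gives < 155000 nM, which is a limit of the assay and not a number. Compound 2 `C=CCN(CC=C)C(=S)N/N=C(/C)c1ccc(N)cc1` and compound 3 `C=CCN(CC=C)C(=S)N/N=C\c1ccccc1O` belong to the same series but carry no result: for compound 2 this assay reports "not determined" (no result reported), and for compound 3 it reports "not determined" (no result reported). Among the compounds with values here, compound 1 thus stands at the limit of < 155000 nM in this assay, at which 1 of the 3 values shown sits, and no step between measured compounds can be drawn from these entries.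

Compound 4 `O=[N+]([O-])c1ccc(/C=N\NC(=S)N(Cc2ccccc2)Cc2ccccc2)o1` differs from compound 1 in one place: 5-nitrofuran-2-yl in place of 2-nitrophenyl on a carbon with a double bond to nitrogen. Within the data shown here, with no measured step to set a scale, the size of the change from compound 1 to compound 4 in this assay cannot be read from the numbers; a shift within the scatter, or a moderate move in either direction, remains open. Compound 4 is expected to sit near 100000 nM, within a range from 30000 nM to 300000 nM. The estimated step that the limit leaves unreadable from compound 1 to compound 4 is meant as a modest, uncertain expectation rather than a firm prediction.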

Compound 4, half-maximal cytotoxic concentration: 158000 nM
Compound 4: the middle estimate sits 1.6-fold (0.20 log units) below what was measured; the measured number falls inside the stated range.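

In this assay, within the data shown here, this position now yields the first single number of the series: compound 4 gives 158000 nM. Compound 1 gives < 155000 nM, which is a limit of the assay and not a number. The step from 2-nitrophenyl to 5-nitrofuran-2-yl on a carbon with a double bond to nitrogen can therefore be read only as a floor, an at least 1.0-fold higher number from compound 1 to compound 4 (0.00 log units; that floor lies within the scatter), so it shows no readable change and leaves the true distance unknown: the limit of < 155000 nM in this assay, at which 1 of the 4 values shown sits.

On these data alone, whether a ring without a nitro group, such as a plain phenyl or a pyridine, would shift the number at this position in this assay remains open. So does the effect of a carboxylic acid in place of the nitro group of 5-nitrofuran-2-yl.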